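The source may hold more compounds than are shown below. What is called first, only, known or untested is meant among the compounds shown, and "the series" means these compounds.

Working notes on the series, read in a functional assay on MCF7 cells (Homo sapiens) for antiproliferative activity, with a stated time of 72 h (a lower number here means that less compound is needed, a higher number that more compound is needed for the effect), throughout. Compound 1 (`O=C(NO)c1cc(F)c(N(Cc2ccc(C3CCOCC3)cc2)C(=O)[C@H]2CCN2S(=O)(=O)c2c(F)c(F)c(F)c(F)c2F)cc1O`) stands at "not determined" (no result reported) and so gives no number to work from. Within the data shown here, compound 2 (`NC(=O)c1ccc(N(Cc2ccc(C3CCCCC3)cn2)C(=O)[C@H]2CCN2S(=O)(=O)c2c(F)c(F)c(F)c(F)c2F)cc1O`) gives 4600 nM and is the only compound with a single number. Compound 3 (`CN(C)C(=O)c1ccc(N(Cc2ccc(C3CCCCC3)cn2)C(=O)[C@H]2CCN2S(=O)(=O)c2c(F)c(F)c(F)c(F)c2F)cc1O`) stands at "not determined" (no result reported) and so has no place on the scale, which leaves its step to compound 4 with no measured starting point.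

Compound 4 (`O=C1NC(=O)c2cc(N(Cc3ccc(C4CCCCC4)cn3)C(=O)[C@H]3CCN3S(=O)(=O)c3c(F)c(F)c(F)c(F)c3F)ccc21`) has yet to be measured. The change in question is a group of 11 heavy atoms (8 carbon, 1 nitrogen, 2 oxygen; one five-membered non-aromatic ring with 1 hetero atom, one six-membered aromatic ring of carbon only) in place of a group of 12 heavy atoms (9 carbon, 1 nitrogen, 2 oxygen; one six-membered aromatic ring of carbon only), on an amide-type nitrogen and it removes the 4-(dimethylcarbamoyl)-3-hydroxyphenyl group from the amide-type nitrogen.

Among the measured compounds shown here, no measured step bears on this change, so no direction can be argued from the data. In this assay the working expectation takes compound 2 at 4600 nM as the sole anchor, held loosely, and foresees no shift from it that would exceed the scatter. Compound 4 is expected at 5000 nM within an estimated range of 1500 nM to 17000 nM as a working estimate.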

Compound 4, half-maximal effective concentration: 7000 nM
Beside the measured number, compound 4's estimate is 1.4-fold (0.15 log units) below it; the measured number falls inside the stated range.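

In this assay, the group on the amide-type nitrogen now has its first readable step: a 1.5-fold higher number from compound 2 to compound 4 (0.18 log units; within the scatter). Among these compounds, the five-membered non-aromatic ring with 1 hetero atom in compound 4 therefore does not separate this compound from compound 2, which the single value available earlier could not show. The step from compound 3 to compound 4 cannot be read, as compound 3 has no number, and nothing on hand accounts for the result.

Still open, on these data alone, is how a carboxylic acid or an amine at this same place on the amide-type nitrogen's aryl group would read against compound 2 and compound 4. Among the compounds shown here, with only one readable step, it also remains open whether any change at this place moves the number beyond the scatter.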